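Working notes: a methyl-for-hydrogen step in a two-point agonist series

The source may report more compounds than this note shows. Statements on the series, on what has been measured and on what is new or still open speak of the compounds shown alone.

Measured so far:
- Compound 1 `COc1cc(C#Cc2ccc(CCC(=O)O)cc2)ccn1`: in an in vitro functional assay on 1321-N1 cells for agonist activity at Free fatty acid receptor 1 (Homo sapiens), read by fluorescence, spectrophotometry and calcium flux (a higher number here means a larger maximal response, a lower number a smaller maximal response), compound 1 reaches 98%.
- Compound 2 `O=C(O)CCc1ccc(C#Cc2ccncc2)cc1`: in this assay compound 2 reaches 100%.

Compound 2 stands highest of the two numbers, with compound 1 nearest; the step of a number 2 percentage points higher from compound 1 to compound 2 (within the scatter) lies within the scatter, so the two cannot be ordered. The change from compound 1 to compound 2 was hydrogen in place of methoxy on an aromatic carbon.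

Compound 3 `Cc1cc(C#Cc2ccc(CCC(=O)O)cc2)ccn1` has not been measured. Its difference from compound 2: methyl in place of hydrogen on an aromatic carbon.

Within the data shown here, only the step from compound 1 to compound 2 bears on this, as it alters the same place on the ring with one nitrogen, and that step stayed within the scatter. A change of similar size at the same place is therefore expected to leave this assay unmoved beyond the scatter, and the expected step is a number 2 percentage points lower from compound 2 to compound 3 (within the scatter). Compound 3 is estimated at 98%, expected between 85% and 108%.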

Compound 3, largest response reached (reported as efficacy), in percent of the reference or control that the assay uses: 102%
Beside the measured number, compound 3's estimate is 4 percentage points below it; measured number inside the range.
By their numbers in this assay, from the lowest: compounds 1, 2 and 3 (each within the scatter of the next).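

In this assay, methyl in place of hydrogen on this aromatic carbon next to the ring nitrogen gives a number 2 percentage points higher from compound 2 to compound 3 (within the scatter), and methyl in place of methoxy gives a number 4 percentage points higher from compound 1 to compound 3 (within the scatter). With a carbon substituent now added to hydrogen and methoxy, all three groups at this place give maximal responses that cannot be told apart, so the lack of separation seen with the first pair also holds for methyl. Nothing at hand accounts for this outcome.

The compounds shown leave open whether a longer chain such as propyl, or an amine, at this place would move the maximal response beyond the scatter. They also leave open how the three compare in the concentration needed to reach that response, which a maximal response alone does not tell.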